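Removing the isobutyl group: cytotoxicity expected to stay low

The source may hold more compounds than are shown below. What is called first, only, known or untested is meant among the compounds shown, and "the series" means these compounds.

In an ADME assay on HepG2 cells (Homo sapiens) for cytotoxicity, read by CellTiter-Glo and resazurin assay, with a stated time of 72 h (on this read-out lower numbers stand for an effect already at smaller amounts and higher numbers for an effect only at larger amounts of compound), compound 1 `CC(C)COc1cccc(-c2ccc(C(=O)N(Cc3cccc(OCCCCCC(=O)O)c3)C(C)C)cc2)c1` gives > 26000 nM, a limit of the assay. Compound 2 `COc1cc(OC)cc(-c2ccc(C(=O)N(Cc3cccc(OCCCCCC(=O)O)c3)C(C)C)cc2)c1` gives > 26000 nM, likewise a limit. Between them lies a step that the two limits leave unreadable from compound 1 to compound 2, because of the limit of > 26000 nM in this assay, at which 2 of the 2 values shown sit. Compound 3 `CC(C)N(Cc1cccc(OCCCCCC(=O)O)c1)C(=O)c1ccc(-c2cccc(O)c2)cc1` differs from compound 1 by hydrogen in place of isobutyl on an oxygen on an aromatic ring. Going by the values given here, no measured step touches this oxygen, and the one measured step gives no readable size, so nothing points to an effect at smaller amounts. Compound 3 is expected to give 30000 nM, between 15000 nM and 80000 nM. The step that the limit leaves unreadable from compound 1 to compound 3 that this estimate means is expected to be none beyond the scatter.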

Compound 3, half-maximal effective concentration: > 26000 nM
Compound 3 ended at the assay's limit (the forecaster's own chance of this, stated with the estimate: 85%); the middle value does not contradict the limit.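

No step between compound 1, compound 2 and compound 3 can be read, because all three stop at the same limit in this assay: the limit of > 26000 nM in this assay, at which 3 of the 3 values shown sit.

Whether any of these compounds has an effect at still larger amounts, and whether their group changes would then matter, stays open.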